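This account rests on a few compounds, and the source may have more. Where it says the series, first, only, none or still open, it means among the compounds named here.

Compound 2 `CN(C)CCCOc1ccc(CN2CC[C@H](NC(=O)c3cccs3)C2)cc1` carries a thiophen-2-yl on the carbonyl carbon of the shared core. In an assay on HEK293 cells for binding affinity to Urotensin-2 receptor (Homo sapiens), read by radioligand binding (on this read-out lower numbers stand for stronger inhibition and higher numbers for weaker inhibition), compound 2 gives only a limit of < 10000 nM rather than a number. Compound 1 `CN(C)CCCOc1ccc(CN2CC[C@H](NC(=O)c3ccc(C#N)cc3)C2)cc1` likewise gives only a limit of < 10000 nM in this assay. The step that the two limits leave unreadable from compound 1 to compound 2 is therefore unreadable, and the limit of < 10000 nM in this assay, at which 2 of the 2 values shown sit, is the whole of the evidence on these steps. Compound 3 `CN(C)CCCOc1ccc(CN2CC[C@H](NC(=O)c3ccc4ccccc4c3)C2)cc1` differs from compound 2 by naphthalen-2-yl in place of thiophen-2-yl on a carbonyl carbon. Within the data shown here, no measured step bears on this change with a readable size. Compound 3 is expected in this assay near 1500 nM, within 150 nM to 12000 nM, an estimated step that the limit leaves unreadable from compound 2 to compound 3.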

Compound 3, inhibition constant: < 10000 nM
Compound 3 was reported as a limit; the forecaster's own chance of this, stated with the estimate: 40%; the middle value lies beyond the limit too.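

No step among compound 1, compound 2 and compound 3 can be read, since all three values are limits: the limit of < 10000 nM in this assay, at which 3 of the 3 values shown sit.

The compounds shown leave open how the thiophen-2-yl, 4-cyanophenyl and naphthalen-2-yl groups on the carbonyl carbon rank against one another.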